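The source may hold more compounds than are shown below. What is called first, only, known or untested is meant among the compounds shown, and "the series" means these compounds.

Among the compounds with values here, in a physicochemical assay, with a stated time of 6 min (on this read-out lower numbers stand for stronger inhibition and higher numbers for weaker inhibition), compound 1 `O=C(Nc1ccc(F)cc1)Nc1nc(-c2cc3ccccc3o2)cs1` gives 1130 nM and holds the lower of the two numbers so far. Compound 2 `COc1ccc(NC(=O)Nc2nc(-c3cc4cc([N+](=O)[O-])ccc4o3)cs2)cc1` gives 121000 nM and lies beyond the scatter from compound 1. Within the data shown here, no two measured compounds differ in one place only, so the series offers no measured step to work from.

The next compound to be read is compound 3 `O=C(Nc1nc(-c2cc3ccccc3o2)cs1)Nc1ccccc1F` and it keeps the core of compound 1. The change is 2-fluorophenyl in place of 4-fluorophenyl on an amide-type nitrogen. The two compounds have the same atoms, joined differently. Among the measured compounds shown here, the expectation therefore rests on the value of compound 1 (1130 nM) and on the modest nature of this swap, with no measured precedent behind it.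

In this assay no step beyond the scatter is expected, with at most a slight lean toward a higher number: the estimated step is (a 1.3-fold higher number from compound 1 to compound 3 (0.12 log units; within the scatter)). For compound 3 the expected value is 1500 nM (estimated range from 500 nM to 5000 nM).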

Compound 3, half-maximal inhibitory concentration: 2630 nM
Estimate against measurement, compound 3: 1.8-fold (0.24 log units) below, and the stated range covers the measured number.
By their numbers in this assay, from the lowest: compound 1; then compound 3; then compound 2.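

In this assay the series now has its first measured step: 2-fluorophenyl in place of 4-fluorophenyl on an amide-type nitrogen gives a 2.3-fold higher number from compound 1 to compound 3 (0.37 log units; beyond the scatter) and stands as a modest change. The two compounds have the same atoms, joined differently, so this step shows that a change in the placement of the fluorine on this phenyl group is enough on its own to move the number beyond the usual scatter, with 4-fluorophenyl holding the lower number of the pair. This position on the amide-type nitrogen therefore responds to an isomeric swap, which compound 1 and compound 2 could not show, since they differ in more than one place. No measurement available here bears on what lies behind this step.

Open, as far as these compounds go, is whether the same direction and size would hold on another core, as this single pair rests on the core of compound 1 alone. Also open, from the compounds shown here alone, is how this position would respond if the fluorine on the phenyl group gave way to a different substituent, such as an amine or a carboxylic acid.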